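A few compounds are considered here, and "the series" means these few. Any claim that something is new, unique, unknown or untested is made for them only; others in the source may bear on it.

Of the compounds shown here, two have been measured so far. Compound 1 `Cc1cc2[nH]c(Nc3ccc(C(=N)N)cc3)nc2cc1Cl` and compound 2 `N=C(N)c1ccc(Nc2nc3ccccc3[nH]2)cc1` share a core that carries an amidine-bearing aryl amine. In an ADME assay on L6 cells (Rattus norvegicus) for cytotoxicity, read by resazurin assay (a lower number here means a stronger inhibitor, a higher number a weaker inhibitor), compound 1 gives 23300 nM. In this assay compound 2 gives 123000 nM, the highest of the two numbers, and its gap to compound 1 lies beyond the usual scatter. Compound 3 `N=C(N)c1ccc(Nc2nc3cc(Cl)ccc3[nH]2)cc1` is compound 2 with one change: chloro in place of hydrogen on an aromatic carbon. For the measured compounds named here, no step between measured compounds isolates this change. Compound 2 stands higher, and compound 1, which also carries a chloro on the fused ring together with a methyl, gives 23300 nM. The expectation for the step of a 2.5-fold lower number from compound 2 to compound 3 (0.39 log units; beyond the scatter) is therefore a move toward a lower number, though of a size that cannot be pinned down from two points. Compound 3 is therefore estimated at 50000 nM, with a range from 20000 nM to 125000 nM.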

Compound 3, half-maximal inhibitory concentration: 46400 nM
The estimate for compound 3 lay 1.1-fold (0.03 log units) above the measured number; measured number inside the range.
By their numbers in this assay, from the lowest: compounds 1 and 3 (each within the scatter of the next); then compound 2.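

In this assay, chloro in place of hydrogen on an aromatic carbon of the six-membered ring of carbon only gives a 2.7-fold lower number from compound 2 to compound 3 (0.42 log units; beyond the scatter) and so moves the number by itself, with no second change alongside it. Hydrogen in place of methyl on an aromatic carbon gives a 2.0-fold higher number from compound 1 to compound 3 (0.30 log units; within the scatter) and so, with the chloro in place, the methyl makes no difference that can be told apart from ordinary repeat variation. Nothing measured here gives a reason for either step.

Going by these compounds, whether this shift is particular to chloro remains open, as a single group cannot show whether fluoro, bromo, methoxy or an amine on the same carbon would move the number the same way, or the opposite way. It is also unknown whether chloro on a different carbon of that ring would give a similar step.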